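From 2-hydroxyethyl to 3-methoxypropyl on compound 1

This account rests on a few compounds, and the source may have more. Where it says the series, first, only, none or still open, it means among the compounds named here.

Values measured so far in a physicochemical assay for solubility, using the shake flask method, in phosphate buffer, with a stated time of 24 h, at pH 6.8 (on this read-out lower numbers stand for lower solubility and higher numbers for higher solubility), are these
compound 1 `COc1cc(/C=C/C(=O)/C=C(/C=C/c2ccc(O)c(OC)c2)NCCO)ccc1O` gives 11800 nM
compound 2 `O=C(/C=C(/C=C/c1ccc(O)cc1)NCCCO)/C=C/c1ccc(O)cc1` gives 128000 nM
compound 3 `COCCCNC(=C\C(=O)/C=C/c1ccc(O)cc1)/C=C/c1ccc(O)cc1` gives 14900 nM

Compound 1 stands at the low end of these three numbers, level with compound 3 within the scatter, while compound 2 shows a higher number, beyond the scatter. Compound 4 `COCCCNC(=C\C(=O)/C=C/c1ccc(O)c(OC)c1)/C=C/c1ccc(O)c(OC)c1` has not yet been measured. Its difference from compound 1 is methoxymethyl in place of hydroxy on a saturated chain carbon, two bonds along the chain from an amine nitrogen and, read one bond further out, this takes 2-hydroxyethyl to 3-methoxypropyl.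

Among the measured compounds shown here, one measured step bears on this change. It is an 8.6-fold lower number from compound 2 to compound 3 (0.93 log units; beyond the scatter) with methyl in place of hydrogen on an oxygen on a saturated carbon, the same end group that compound 4 carries. That step is beyond the scatter, but it was seen on a different core. For the measured compounds named here, no measured pair shows the same replacement on the core of compound 1, and none shows the longer chain alone. In this assay a move to a lower number is therefore expected, similar in size or somewhat smaller, given that compound 1 already stands at 11800 nM on the low side. The expected step is a 4.7-fold lower number from compound 1 to compound 4 (0.67 log units; beyond the scatter) on this estimate. For compound 4 the estimated value is 2500 nM (expected range 700 nM to 8000 nM).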

Compound 4, solubility: 9660 nM
The estimate for compound 4 lay 3.9-fold (0.59 log units) below the measured number, and the stated range ends below it.
By their numbers in this assay, from the lowest: compounds 4, 1 and 3 (each within the scatter of the next); then compound 2.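

In this assay, 3-methoxypropyl in place of 2-hydroxyethyl on the core of compound 1 gives a 1.2-fold lower number from compound 1 to compound 4 (0.09 log units; within the scatter) and so leaves the two compounds level. On the other core, the methyl in place of hydrogen on the chain oxygen gave an 8.6-fold lower number from compound 2 to compound 3 (0.93 log units; beyond the scatter) and thus a step beyond the scatter, so the same methoxy chain end does not bring a step of that kind on every core shown. Nothing available here accounts for this difference between the two cores.

From the compounds shown here alone, the change from compound 1 to compound 4 alters the chain length and the end group together, so what each contributes on this core stays open, and 3-hydroxypropyl or 2-methoxyethyl on the core of compound 1 would be needed to separate them. Going by these compounds, it also remains open whether this position stays as flat for chain ends of another kind, such as an amine or a carboxylic acid, or whether the level result holds only for the hydroxy and methoxy ends seen so far.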